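A few compounds are considered here, and "the series" means these few. Any claim that something is new, unique, unknown or untested is made for them only; others in the source may bear on it.

Notes on a functional assay on DU-145 cells (Homo sapiens) for inhibition, read by trypan blue exclusion, with a stated time of 96 h; a higher number here means a weaker inhibitor of growth, a lower number a stronger inhibitor of growth:
- compound 1 `O=C(/C(=C\c1ccc(O)c([N+](=O)[O-])c1)S(=O)(=O)Cc1ccccc1Cl)c1ccc(Cl)cc1`: 10000 nM
- compound 2 `CCOc1ccc(/C=C(/Sc2ccc(C)cc2)C(=O)c2ccc(Cl)cc2)cc1OC`: 25000 nM

Compound 2 holds the higher of the two numbers, and its gap to compound 1 lies beyond the scatter. Compound 3 `CCOc1ccc(/C=C(\C(=O)c2ccc(Cl)cc2)S(=O)(=O)Cc2ccccc2Cl)cc1OC` carries (2-chlorobenzyl)sulfonyl in place of (4-methylphenyl)sulfanyl on a double-bonded chain carbon bound to a carbonyl carbon and a double-bonded chain carbon. Going by the values given here, no measured step covers this change. In this assay a moderate move to a lower number is expected, a reading that rests only on compound 1 at 10000 nM. The expected size is a 3.6-fold lower number from compound 2 to compound 3 (0.55 log units; beyond the scatter). For compound 3 the estimated value is 7000 nM, with an expected range of 1500 nM to 30000 nM.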

Compound 3, concentration for 50% growth inhibition: 10000 nM
Beside the measured number, compound 3's estimate is 1.4-fold (0.15 log units) below it; the measured number falls inside the stated range.
By their numbers in this assay, from the lowest: compounds 1 and 3 (each within the scatter of the next); then compound 2.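

In this assay, (2-chlorobenzyl)sulfonyl in place of (4-methylphenyl)sulfanyl on a double-bonded chain carbon gives a 2.5-fold lower number from compound 2 to compound 3 (0.40 log units; beyond the scatter), a modest step at this position. With (2-chlorobenzyl)sulfonyl held, 4-ethoxy-3-methoxyphenyl in place of 4-hydroxy-3-nitrophenyl gives no change at the digits printed from compound 1 to compound 3 (within the scatter), so this pair does not separate the two aryl groups. Nothing at hand bears on a cause for either step.

Open, as far as these compounds go, is whether the sulfonyl or the 2-chlorobenzyl part carries the step, which (4-methylphenyl)sulfonyl would help to separate. Also open, from the compounds shown here alone, is how an amine or a carboxylic acid on the aryl ring would read here.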